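The source may hold more compounds than are shown below. What is called first, only, known or untested is meant among the compounds shown, and "the series" means these compounds.

Measured compounds:
- compound 1, `c1ccc(C2CCc3nc[nH]c3C2)cc1`, in a functional assay on CHO cells for agonist activity at Alpha-1A adrenergic receptor (Homo sapiens), read by FLIPR and calcium flux; on this read-out lower numbers stand for an effect already at smaller amounts and higher numbers for an effect only at larger amounts of compound: 234 nM; 123 nM; 315 nM (3 entries)
- compound 2, `Fc1ccccc1C1Cc2nccn2C1`, in this assay: 42 nM
- compound 3, `c1ccc(C2Cc3nccn3C2)cc1`, in this assay: 83 nM; 73 nM; > 10000 nM; 70 nM (4 entries)

Compound 2 stands with the only number shown for it in this assay; two further entries for compound 2 give no single number. Compound 1 shows three entries, all of which lie within the scatter of one another (the several entries of compound 1 in this assay, 234 nM; 123 nM; 315 nM (3 entries)). Among the entries of compound 3, one is a limit of the assay and not a number (the several entries of compound 3 in this assay, 83 nM; 73 nM; > 10000 nM; 70 nM (4 entries)). The three numbers of compound 3 agree with each other within the scatter.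

Compound 4, `FC(F)Oc1ccccc1C1Cc2nccn2C1`, has not yet been measured in this assay. It differs from compound 2 in one place: difluoromethoxy in place of fluoro on an aromatic carbon. For the measured compounds named here, no measured pair in this set shares that change, so no measured step can be pointed to. On the numbers available, the step from compound 2 to compound 4 is expected to be small, with no clear direction beyond the scatter. Compound 4 is therefore expected to give about 80 nM in this assay, within a range from 20 nM to 320 nM, which corresponds to the expected step of a 1.9-fold higher number from compound 2 to compound 4 (0.28 log units; within the scatter).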

Compound 4, half-maximal effective concentration: 11 nM
Estimate against measurement, compound 4: 7.3-fold (0.86 log units) above, and the stated range ends above it.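

In this assay, for the compounds shown here, difluoromethoxy in place of fluoro on an aromatic carbon, ortho to a group of 8 heavy atoms, gives a 3.8-fold lower number from compound 2 to compound 4 (0.58 log units; beyond the scatter) and thus the first step in this set between compounds that differ in one place. At this position a group with more heavy atoms and a hydrogen-bond acceptor goes with a lower number, not a higher one, although this rests on a single pair. Nothing measured here gives a reason for this step.

The compounds shown leave open whether methoxy, trifluoromethoxy or an amine at the same place would move the number in the same direction. They also leave open whether the same change would give a similar step on the core of compound 1.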